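The compounds below may be only part of what the source reports. "The series", "measured", "known", "first", "only" and "open" are said of these compounds alone.

Three compounds have been measured in an assay on isolated protein for inhibition of Fatty-acid amide hydrolase 1 (Homo sapiens), read by scintillation counting, with stated times of 30 min and 10 min; a higher number here means a weaker inhibitor, a lower number a stronger inhibitor:

Compound 1, `CN1CCN(C(=O)c2cccc(CN3CCN(C(=O)n4nnc5ccccc54)CC3)c2)CC1`, gives 1380 nM.
Compound 2, `O=C(Nc1ccccc1)c1cccc(CN2CCN(C(=O)n3nnc4ccccc43)CC2)c1`, gives 35 nM.
Compound 3, `O=C(c1cc(N2CCN(C(=O)n3nnc4ccccc43)CC2)ccc1[N+](=O)[O-])N1CCCCC1`, gives 2290 nM.

Among these three numbers compound 3 stands highest. Its nearest neighbour is compound 1, whose value lies within the scatter of that of compound 3, so the two cannot be set in order; compound 2 lies far below both, beyond the scatter.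

The step from compound 3 leads to compound 4, `O=C(NC1CCCCC1)c1cc(N2CCN(C(=O)n3nnc4ccccc43)CC2)ccc1[N+](=O)[O-]`, not yet measured. The change is cyclohexylamino in place of piperidin-1-yl on a carbonyl carbon. One measured step is of the same kind, a cyclic amine on a carbonyl carbon exchanged for an amino group bearing a ring: a 39-fold lower number from compound 1 to compound 2 (1.60 log units; beyond the scatter). That step was large, but the entering group there was anilino rather than cyclohexylamino, and the core of compound 1 differs from the core of compound 3, so the full size of that step should not be carried over unchanged. A lower number for compound 4 than for compound 3 is nevertheless expected, in the same direction as the step from compound 1 to compound 2, of moderate size; the expected step is a 5.7-fold lower number from compound 3 to compound 4 (0.76 log units; beyond the scatter). Compound 4 is therefore estimated at 400 nM, with a range from 100 nM to 1500 nM.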

Compound 4, half-maximal inhibitory concentration: 490 nM
The estimate for compound 4 lay 1.2-fold (0.09 log units) below the measured number; the range from low to high includes it.
By their numbers in this assay, from the lowest: compound 2; then compound 4; then compounds 1 and 3 (each within the scatter of the next).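

In this assay, among these compounds, replacing piperidin-1-yl with cyclohexylamino on a carbonyl carbon whose other neighbour is an aromatic carbon gives a 4.7-fold lower number from compound 3 to compound 4 (0.67 log units; beyond the scatter), so a lower number after such an exchange is no longer seen only with anilino entering in place of 4-methylpiperazin-1-yl, as in a 39-fold lower number from compound 1 to compound 2 (1.60 log units; beyond the scatter), but also with a different entering group, a different leaving group and a different core. The two steps run in the same direction, and neither the shown steps nor compound 3 goes against this, yet the new step is modest where the earlier one was large, and the differences in groups and cores leave that contrast in size unassigned. The change to compound 4 also brings several differences at once, since the entering group adds a hydrogen-bond donor and a heavy atom and has a ring of carbon only, and nothing measured here explains the lower number or separates these differences.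

Going by these compounds, it remains open whether anilino on the core of compound 3 would give a lower number than cyclohexylamino does. On these data alone, it also remains open whether N-methyl-N-cyclohexylamino, which keeps the carbon ring but has no amide hydrogen, would stay near compound 4 or return towards compound 3.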